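A few compounds are considered here, and "the series" means these few. Any claim that something is new, unique, unknown or untested is made for them only; others in the source may bear on it.

Measured compounds: compound 1 `O=C(SCCO)SCc1ccc(Cl)cc1Cl`, 310 nM; compound 2 `O=C(SCCc1ccc(O)cc1)SCc1ccc(Cl)cc1Cl`, 100 nM.

Within the data shown here, in an assay on isolated protein for inhibition of Indoleamine 2,3-dioxygenase 1 (Homo sapiens), with a stated time of 60 min (a lower number here means a stronger inhibitor, a higher number a weaker inhibitor), compound 2 holds the lower of the two numbers; the single measured step, a 3.1-fold lower number from compound 1 to compound 2 (0.49 log units; beyond the scatter), separates it from compound 1. Compound 3 `COc1ccc(CCSC(=O)SCc2ccc(Cl)cc2Cl)cc1` differs from compound 2 by methyl in place of hydrogen on an oxygen on an aromatic ring. Among the measured compounds shown here, no measured step touches that oxygen: the step of a 3.1-fold lower number from compound 1 to compound 2 (0.49 log units; beyond the scatter) exchanged the whole group on the chain, not the hydrogen on the phenol oxygen, so it does not bear directly on this change. He therefore expects no step beyond the scatter, with the direction open. Compound 3 is expected to give 150 nM (range 50 nM to 500 nM), an expected step of a 1.5-fold higher number from compound 2 to compound 3 (0.18 log units; within the scatter).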

Compound 3, half-maximal inhibitory concentration: 200 nM
Beside the measured number, compound 3's estimate is 1.3-fold (0.12 log units) below it; the measured number falls inside the stated range.
By their numbers in this assay, from the lowest: compounds 2, 3 and 1 (each within the scatter of the next, the first and the last beyond it).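

In this assay, the step of a 2.0-fold higher number from compound 2 to compound 3 (0.30 log units; within the scatter) shows that methyl can take the place of the hydrogen on this oxygen without a change beyond the scatter, so in this pair the free hydroxy is not needed for the measured inhibition. The earlier step exchanged the whole group on the chain and could not show this. Nothing available explains this result. Still open, as far as these compounds go, is how an ethoxy or benzyloxy group on this oxygen would compare, or an amine or carboxylic acid in place of the hydroxy. From the compounds shown here alone, a longer chain carrying the aromatic ring also remains open.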